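The source may hold more compounds than are shown below. What is called first, only, known or untested is meant among the compounds shown, and "the series" means these compounds.

Measured so far in a functional assay on HepG2 cells (Homo sapiens) for inhibition, read by MTT assay; a lower number here means a stronger inhibitor of growth, a higher number a weaker inhibitor of growth:
- compound 1 `COc1cc2oc(-c3cccc(NC(=O)c4ccc(Br)cc4)c3)cc(=O)c2c(OC)c1OC`: 8850 nM
- compound 2 `COc1cc2oc(-c3cccc(NC(=O)c4ccc(C(F)(F)F)cc4)c3)cc(=O)c2c(OC)c1OC`: 61100 nM

Of these two, compound 2 has the higher number, at 61100 nM, and is the weaker inhibitor of growth. The next compound, compound 3 `COc1ccc(C(=O)Nc2cccc(-c3cc(=O)c4c(OC)c(OC)c(OC)cc4o3)c2)cc1`, has methoxy in place of trifluoromethyl on an aromatic carbon. Going by the values given here, only one measured step bears on this change: a 6.9-fold higher number from compound 1 to compound 2 (0.84 log units; beyond the scatter), a modest step beyond the scatter, with trifluoromethyl replacing bromo. Among the compounds with values here, no methoxy compound has been measured, so this single step gives only a rough guide to size. A step of similar or smaller size towards a lower number is expected, and the estimated step is a 3.1-fold lower number from compound 2 to compound 3 (0.49 log units; beyond the scatter). For compound 3 the expected value in this assay is 20000 nM, with an estimated range of 6000 nM to 65000 nM.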

Compound 3, concentration for 50% growth inhibition: 22200 nM
Compound 3: middle estimate off by 1.1-fold (0.05 log units), on the low side; the range from low to high includes it.
By their numbers in this assay, from the lowest: compound 1; then compound 3; then compound 2.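

Methoxy in place of trifluoromethyl shows a 2.8-fold lower number from compound 2 to compound 3 (0.44 log units; beyond the scatter) in this assay and so this place, para to a large group, can move the number down as well as up. Methoxy does not return to the bromo level, however, with a 2.5-fold higher number from compound 1 to compound 3 (0.40 log units; beyond the scatter) still setting the two apart. The three groups now stand apart from one another beyond the scatter, with bromo giving the lowest number, trifluoromethyl the highest and methoxy lying in the middle.

No evidence at hand accounts for this order. Open questions are where an amine, a carboxylic acid, or a longer chain such as butoxy would fall at this place, and whether chloro or iodo would stay close to bromo.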